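Adding a Second Chloro Group to a Myeloperoxidase Inhibitor

The source may report more compounds than this note shows. Statements on the series, on what has been measured and on what is new or still open speak of the compounds shown alone.

Of the compounds shown here, three sharing one core have been measured in an assay for inhibition of Myeloperoxidase (Homo sapiens), read by Amplex Red, with stated times of 10 min and 15 min; a higher number here means a weaker inhibitor, a lower number a stronger inhibitor. Compound 1, `Nc1cc(OCc2ccccc2Cl)c2nn[nH]c2n1`, gives 26 nM. Compound 2, `Nc1cc(OCc2cccc(-c3cccc(F)c3)c2)c2nn[nH]c2n1`, gives 21 nM in this assay. Compound 3, `Nc1cc(OCc2cc(-c3cccc(F)c3)ccc2Cl)c2nn[nH]c2n1`, gives 24 nM in this assay. Compound 1 and compound 3 differ in one place, and the step is a 1.1-fold lower number from compound 1 to compound 3 (0.03 log units; within the scatter). Compound 2 and compound 3 also differ in one place, described as chloro in place of hydrogen on an aromatic carbon, and the step in this assay is a 1.1-fold higher number from compound 2 to compound 3 (0.06 log units; within the scatter). The difference between the core of compound 1 and the core of compound 2 is not broken down here; what their two values show is that they lie close together.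

Compound 4, `Nc1cc(OCc2c(Cl)cccc2Cl)c2nn[nH]c2n1`, has not yet been measured. It differs from compound 1 in one place: chloro in place of hydrogen on an aromatic carbon. Among the measured compounds shown here, this is the same kind of change as the one from compound 2 to compound 3, but not the same: in compound 3 the entering chloro group sits para to a 3-fluorophenyl group, whereas in compound 4 it sits meta to a chloro group. For the measured compounds named here, because the one measured instance of this kind of change gave a 1.1-fold higher number from compound 2 to compound 3 (0.06 log units; within the scatter), the expectation for compound 4 in this assay is a step of a 1.2-fold higher number from compound 1 to compound 4 (0.06 log units; within the scatter), which would stay within the usual scatter. Compound 4 is therefore estimated at 30 nM, with a likely range from 12 nM to 75 nM.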

Compound 4, half-maximal inhibitory concentration: 6.7 nM
The estimate for compound 4 lay 4.5-fold (0.65 log units) above the measured number; measured number below the stated range.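

In this assay, chloro in place of hydrogen on an aromatic carbon gives a 3.9-fold lower number from compound 1 to compound 4 (0.59 log units; beyond the scatter), so on this core the added chloro group comes with a stronger inhibitor, while on the core of compound 2 the same kind of change produced no difference that stands out from the scatter. Among the compounds shown here, the same kind of change therefore did not carry over from one core to the other with the same size, and a step measured on one core was a poor guide to the step on the other: the same change on two cores in this assay, a 1.1-fold higher number (0.06 log units; within the scatter) from compound 2 to compound 3 and a 3.9-fold lower number (0.59 log units; beyond the scatter) from compound 1 to compound 4, 4.4-fold (0.65 log units) apart, beyond the scatter of two such steps With only one pair on each side, this shows that the two cores respond differently, but it does not show which difference between them accounts for the gap, and it gives no rule for any other core.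

A fluoro, methyl or methoxy group at the place taken by the new chloro group in compound 4 would help show whether the gain is particular to chloro. Also open, from the compounds shown here alone, is whether the gain would survive if a 3-fluorophenyl group were added to compound 4, which would bring the features of compound 3 and compound 4 together.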